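The source may hold more compounds than are shown below. What is called first, only, known or untested is meant among the compounds shown, and "the series" means these compounds.

Compound 1 `CCOc1ccccc1N1CCN(CCCCn2ncc(=O)n(C)c2=O)CC1` and compound 2 `Cn1c(=O)cnn(CCCCN2CCN(c3ccccc3C#N)CC2)c1=O` share one core and differ only in the group on the aromatic carbon of the phenyl ring. In an assay for displacement of a labelled ligand from Adrenergic receptor alpha-1 (Homo sapiens) (a lower number here means a stronger inhibitor, a higher number a weaker inhibitor), compound 1 gives 1.8 nM, while compound 2 gives 7.3 nM. Among the measured compounds shown here, the step of a 4.1-fold higher number from compound 1 to compound 2 (0.61 log units; beyond the scatter) is the only one measured so far, and compound 2 therefore holds the highest of the two numbers in this assay, its nearest neighbour being compound 1.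

Compound 3 `Cn1c(=O)cnn(CCCCN2CCN(c3ccccc3S)CC2)c1=O` is not yet measured. Relative to compound 2 it carries sulfanyl in place of cyano on an aromatic carbon. For the measured compounds named here, no measured step involves a sulfanyl group, so the only bearing comes from the single step from compound 1 to compound 2, which shows that a change of the group at this position shifts the number modestly but beyond the scatter. On that basis the expectation for compound 3 in this assay is a step of a 1.5-fold lower number from compound 2 to compound 3 (0.16 log units; within the scatter), leaning toward a number somewhat below that of compound 2, since the cyano compound 2 holds the highest value of the two. Compound 3 is estimated at 5 nM, with a range from 1.5 nM to 17 nM.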

Compound 3, inhibition constant: > 10000 nM
Compound 3 was reported as a limit; the forecaster's own chance of this, stated with the estimate: 2%; at least 2000-fold (3.30 log units) between middle value and limit.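

Compound 3 stands at a limit of the assay and not at a number in this assay: the limit of > 10000 nM in this assay, at which 1 of the 3 values shown sits.

The group on this aromatic carbon, ortho to a large group, can therefore decide between strong binding and none detectable within the assay's range. Replacing cyano with sulfanyl gives an at least 1300-fold higher number from compound 2 to compound 3 (3.13 log units; beyond the scatter), and replacing ethoxy with sulfanyl gives an at least 5500-fold higher number from compound 1 to compound 3 (3.74 log units; beyond the scatter), whereas the earlier change gave only a 4.1-fold higher number from compound 1 to compound 2 (0.61 log units; beyond the scatter). Both new steps rest on the limit, so they fix only a minimum size, and the change from cyano to sulfanyl also brings in one hydrogen-bond donor where cyano has none.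

One compound cannot separate the contribution of the sulfur from that of the hydrogen on it, so the cause of the loss stays open. A methylsulfanyl group would keep the sulfur without that hydrogen, while a hydroxyl group or an amine at the same place would keep a hydrogen on a different atom, and the compounds shown do not say how any of these would read in this assay.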